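A few compounds are considered here, and "the series" means these few. Any claim that something is new, unique, unknown or untested is made for them only; others in the source may bear on it.

In a functional assay on K562 cells (Homo sapiens) for cytotoxicity, read by MTT assay, with a stated time of 48 h (a lower number here means a stronger inhibitor, a higher number a weaker inhibitor), compound 1 (`Cc1ccc(CN2CCN(C(=O)CN[C@H]3CCN(S(=O)(=O)Cc4ccccc4)C3)CC2)cc1`), which carries 4-methylphenyl, gives 8200 nM. Compound 2 (`O=C(CN[C@H]1CCN(S(=O)(=O)Cc2ccccc2)C1)N1CCN(Cc2ccccc2Cl)CC1`), with 2-chlorophenyl in that place, gives 9000 nM, and a 1.1-fold higher number from compound 1 to compound 2 (0.04 log units; within the scatter) does not separate the two. Compound 3 (`Cc1cc(C)c(CN2CCN(C(=O)CN[C@H]3CCN(S(=O)(=O)Cc4ccccc4)C3)CC2)c(C)c1`), with 2,4,6-trimethylphenyl, gives 3300 nM, the lowest number of the three. It stands apart from both others: a 2.5-fold lower number from compound 1 to compound 3 (0.40 log units; beyond the scatter) and a 2.7-fold lower number from compound 2 to compound 3 (0.44 log units; beyond the scatter) are modest steps.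

Compound 4 (`O=C(CN[C@H]1CCN(S(=O)(=O)Cc2ccccc2)C1)N1CCN(Cc2c(Cl)cccc2Cl)CC1`) has 2,6-dichlorophenyl in place of 2,4,6-trimethylphenyl on a saturated chain carbon bound to an amine nitrogen in a ring. For the measured compounds named here, no measured step makes this exact change. Going by the values given here, the nearest evidence is compound 2, the only measured compound with a chlorine-bearing phenyl group, and a 2.7-fold lower number from compound 2 to compound 3 (0.44 log units; beyond the scatter) shows the trimethylphenyl compound holding the lower number against it. Only part of that gap is expected to return in this assay, since compound 4 is a different chlorinated group from that of compound 2. The direction is expected to be upward, and the size smaller than the measured modest steps, possibly not beyond the scatter. The expected change is a 1.7-fold higher number from compound 3 to compound 4 (0.22 log units; within the scatter). Compound 4 is estimated at 5500 nM, within an expected range of 2400 nM to 12000 nM.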

Compound 4, half-maximal inhibitory concentration: 28400 nM
For compound 4 the middle estimate is 5.2-fold (0.71 log units) below the measured one; measured number above the stated range.
By their numbers in this assay, from the lowest: compound 3; then compounds 1 and 2 (each within the scatter of the next); then compound 4.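

In this assay, for the compounds shown here, an 8.6-fold higher number from compound 3 to compound 4 (0.93 log units; beyond the scatter) shows that this place, on a saturated chain carbon bound to an amine nitrogen in a ring, can move the number further than any step among the earlier compounds did, and the direction is upward. A single further change also counts here: chloro in place of hydrogen on an aromatic carbon gives a 3.2-fold higher number from compound 2 to compound 4 (0.50 log units; beyond the scatter), although compound 1 and compound 2 could not be told apart, and a 3.5-fold higher number from compound 1 to compound 4 (0.54 log units; beyond the scatter) sets the 2,6-dichlorophenyl compound apart from the 4-methylphenyl compound as well. Compound 3, with 2,4,6-trimethylphenyl, and compound 4, with 2,6-dichlorophenyl, stand at the two ends of the order among these compounds.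

Nothing available here accounts for these steps. A 2,6-dimethylphenyl or a 2,4,6-trichlorophenyl group at this place would help show whether the rise follows the chlorines themselves or the pattern in which they stand.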